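Chlorine on the Core of Two Benzyl Purines

The source may hold more compounds than are shown below. What is called first, only, known or untested is meant among the compounds shown, and "the series" means these compounds.

Three compounds have been measured in a functional assay on IGROV-1 cells (Homo sapiens) for cytotoxicity, read by sulforhodamine B assay, with a stated time of 48 h; a lower number here means that less compound is tolerated, a higher number that more compound is tolerated:
compound 1 `ClCc1ccccc1Cn1cnc2c(Cl)nc(Cl)nc21`, which gives 7070 nM;
compound 2 `ClCc1ccccc1Cn1cnc2c(Cl)ncnc21`, which gives 55000 nM;
compound 3 `ClCc1cccc(Cn2cnc3c(Cl)ncnc32)c1`, for which only a limit is reported.

For compound 3 this assay gives no number but a limit, > 100000 nM. This is the limit of > 100000 nM in this assay, at which 1 of the 3 values shown sits.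

Compound 1 differs from compound 2 by chloro in place of hydrogen on an aromatic carbon. That change gave a 7.8-fold lower number from compound 2 to compound 1 (0.89 log units; beyond the scatter). The cores of compound 3 and compound 2 differ, but how they differ is not broken down here.

Compound 4 `ClCc1cccc(Cn2cnc3c(Cl)nc(Cl)nc32)c1` has not yet been measured in this assay. It differs from compound 3 by chloro in place of hydrogen on an aromatic carbon, the same change as that between compound 2 and compound 1, at a place described in the same words. A step of a size like the earlier one is expected, an at least 4.0-fold lower number from compound 3 to compound 4 (0.60 log units; beyond the scatter), though its starting point is uncertain because compound 3 stands only at the limit of > 100000 nM in this assay, at which 1 of the 3 values shown sits. Compound 4 is therefore estimated at 25000 nM, expected to lie between 8000 nM and 100000 nM.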

Compound 4, concentration lethal to 50% of the cells: 20000 nM
Compound 4: the middle estimate sits 1.3-fold (0.10 log units) above what was measured, within the range that was stated.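

In this assay, chloro in place of hydrogen on an aromatic carbon gave an at least 5.0-fold lower number from compound 3 to compound 4 (0.69 log units; beyond the scatter), so the change lowered the number on the second core as it had on the first: the same change on two cores in this assay, a 7.8-fold lower number (0.89 log units; beyond the scatter) from compound 2 to compound 1 and an at least 5.0-fold lower number (0.69 log units; beyond the scatter) from compound 3 to compound 4; the limit leaves it open whether they differ

Compound 3 is known here only through a limit, > 100000 nM, and not through a number. The two pairs therefore show that the direction of the change carried from one core to the other, but not whether its size was the same on both, and two pairs do not make a rule for the whole series.

The compounds shown carry only hydrogen or chloro on the carbon between two ring nitrogen atoms, so it remains open what an amine, a methoxy group or a longer chain would do at that place. From the compounds shown here alone, it also remains open whether the step seen on these two cores would appear on any other core or in other cells.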